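Switching the dichlorobenzyl pattern on a thioether chalcone-type core

The compounds below may be only part of what the source reports. "The series", "measured", "known", "first", "only" and "open" are said of these compounds alone.

This account follows one change within a small series tested in a functional assay on DU-145 cells (Homo sapiens) for inhibition, read by trypan blue exclusion, with a stated time of 96 h; on this read-out higher numbers stand for weaker inhibition of growth and lower numbers for stronger inhibition of growth. Compound 1 `COc1cc(OC)c(/C=C(/SCc2ccc(Cl)c(Cl)c2)C(=O)c2ccc(Cl)cc2)c(OC)c1` gives 10000 nM in this assay. Compound 2 `Cc1ccc(CS/C(=C/c2sccc2C)C(=O)c2ccc(Cl)cc2)cc1`, which carries a different aryl group on the core, gives 10000 nM in this assay. The two values stand level at the digits shown, so compound 1 stands together with compound 2 and no ordering between them can be drawn.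

The compound still to be measured is compound 3 `COc1cc(OC)c(/C=C(/SCc2ccc(Cl)cc2Cl)C(=O)c2ccc(Cl)cc2)c(OC)c1`. Compared with compound 1, the change is 2,4-dichlorophenyl in place of 3,4-dichlorophenyl on a saturated chain carbon bound to a sulfur. The two compounds hold the same atoms, joined differently.

No pair of measured compounds in the series differs in one place, so nothing is shown about how a change of this kind moves the read-out. With compound 1 and compound 2 sitting at the same value despite a larger structural gap between them, compound 3 is expected to stay within the scatter of compound 1, with a step of no change at the digits printed from compound 1 to compound 3 (within the scatter) expected in this assay. Compound 3 is therefore estimated at 10000 nM in this assay, within a range from 5000 nM to 20000 nM.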

Compound 3, concentration for 50% growth inhibition: 1000 nM
Beside the measured number, compound 3's estimate is 10-fold (1.00 log units) above it, outside the stated range (below it).
By their numbers in this assay, from the lowest: compound 3; then compounds 1 and 2 (each within the scatter of the next).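

In this assay, exchanging 3,4-dichlorophenyl for 2,4-dichlorophenyl on a saturated chain carbon bound to a sulfur gives a 10-fold lower number from compound 1 to compound 3 (1.00 log units; beyond the scatter), so the read-out at this position depends on how the two chlorines are arranged on the ring, even though the atoms themselves stay the same. Until this result, no pair in the series differed in one place, and so nothing had shown that this position could move the read-out at all. No measurement shown here accounts for the step, which stands as an observation without an explanation.

A single pair on one core in one assay cannot tell whether the same exchange would carry over to the core of compound 2, which differs from compound 3 in more than one place. Nor do the compounds shown say how the read-out in this assay would respond to a pyridine ring, an amine or a carboxylic acid in place of the 2,4-dichlorophenyl on that saturated chain carbon bound to a sulfur.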